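Carbamate chain length in an aryl selenocyanate series

The source may report more compounds than this note shows. Statements on the series, on what has been measured and on what is new or still open speak of the compounds shown alone.

Measured compounds:
compound 1 `C=CCOC(=O)Nc1ccc([Se]C#N)cc1`: 44700 nM
compound 2 `CCOC(=O)Nc1ccc([Se]C#N)cc1`: 39200 nM

Both compounds share the same core and differ only in the group on the saturated chain carbon bound to the oxygen next to the carbonyl group. In a functional assay on PC-3 cells (Homo sapiens) for cytotoxicity, read by MTT assay, with a stated time of 72 h (a higher number here means a weaker inhibitor of growth, a lower number a stronger inhibitor of growth), compound 1 gives 44700 nM; compound 2 gives 39200 nM. Among the measured compounds shown here, the one measured step, a 1.1-fold lower number from compound 1 to compound 2 (0.06 log units; within the scatter), shows that swapping methyl for vinyl there leaves the read-out essentially unchanged. Compound 2 therefore holds the lowest of the two numbers, but only by a margin within the scatter, so no order between compound 2 and compound 1 can be claimed.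

Compound 3 `CCCCCCOC(=O)Nc1ccc([Se]C#N)cc1` extends the chain of compound 2: butyl in place of hydrogen on a saturated chain carbon, two bonds along the chain from an oxygen next to a carbonyl group. For the measured compounds named here, no measured step covers chain lengthening of this kind; the step from compound 1 to compound 2 bears on it only in showing that a small change at this chain carbon did not move the number. The expected change from compound 2 to compound 3 is accordingly no step beyond the scatter, a 1.1-fold lower number from compound 2 to compound 3 (0.05 log units; within the scatter), with wide uncertainty because of the absence of a direct precedent. Compound 3 is estimated at 35000 nM, in the range 15000 nM to 80000 nM.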

Compound 3, concentration for total growth inhibition: 44600 nM
The estimate for compound 3 lay 1.3-fold (0.11 log units) below the measured number, and the stated range covers the measured number.
By their numbers in this assay, from the lowest: compounds 2, 3 and 1 (each within the scatter of the next).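

In this assay, butyl in place of hydrogen on a saturated chain carbon, two bonds along the chain from an oxygen next to a carbonyl group, gives a 1.1-fold higher number from compound 2 to compound 3 (0.06 log units; within the scatter), so adding 4 heavy atoms of carbon here keeps the number within the scatter, a result that reaches well beyond the small swap of methyl for vinyl seen in the earlier pair. The wider comparison gives a 1.0-fold lower number from compound 1 to compound 3 (0.00 log units; within the scatter), so compound 1, compound 2 and compound 3 all lie within the scatter of one another and the chains shown set no order among them. No supporting measurement is available to explain this result.

On these data alone, a longer chain such as decyl, or a chain ending in an amine or a carboxylic acid, remains open as a test of whether this position can move the number beyond the scatter. Also open is whether a phenyl ring at the end of the chain would separate from the three compounds shown.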